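The source may hold more compounds than are shown below. What is called first, only, known or untested is meant among the compounds shown, and "the series" means these compounds.

Compound 1 `CCCn1cnc2c(N)nc(NCCCc3ccccc3)nc21` gives 12600 nM in an assay on CHO cells for displacement of a labelled ligand from transmembrane domain-containing protein TMIGD3 (Homo sapiens); a higher number here means a weaker inhibitor, a lower number a stronger inhibitor. Within the data shown here, compound 2 `CCCn1c(Br)nc2c(N)nc(NCCCc3ccccc3)nc21` gives 1950 nM; the step of a 6.5-fold lower number from compound 1 to compound 2 (0.81 log units; beyond the scatter) is the only measured single change. Compound 3 `CCCn1c(-c2ccco2)nc2c(N)nc(NCc3ccccc3)nc21` gives 29 nM, the lowest of the three numbers, with compound 2 nearest and compound 1 furthest. Compound 4 `CCCn1c(-c2ccco2)nc2c(N)nc(NCCCc3ccccc3)nc21` differs from compound 3 by phenethyl in place of phenyl on a saturated chain carbon bound to a nitrogen on an aromatic ring. Among the measured compounds shown here, no measured step bears on this chain lengthening: compounds 1 and 2 carry the longer chain but also lack the furyl group of compound 3, so their values give no clean comparison. The step of a 1.6-fold higher number from compound 3 to compound 4 (0.19 log units; within the scatter) is therefore expected to stay within the scatter, or be at most modest. Compound 4 is estimated at 45 nM, range 12 nM to 180 nM.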

Compound 4, inhibition constant: 266 nM
For compound 4 the middle estimate is 5.9-fold (0.77 log units) below the measured one, outside the stated range (above it).
By their numbers in this assay, from the lowest: compound 3; then compound 4; then compound 2; then compound 1.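

With furan-2-yl held fixed, benzyl to 3-phenylpropyl is not a neutral change at this position: it gives a 9.2-fold higher number from compound 3 to compound 4 (0.96 log units; beyond the scatter) and costs affinity. With 3-phenylpropyl held fixed, furan-2-yl on the aromatic carbon gives a 47-fold lower number from compound 1 to compound 4 (1.68 log units; beyond the scatter) against hydrogen and a 7.3-fold lower number from compound 2 to compound 4 (0.87 log units; beyond the scatter) against bromo, so that position still drives the number on the longer chain. No evidence here accounts for either effect. Open, from the compounds shown here alone, is whether the benzyl advantage holds with hydrogen or bromo in place of furan-2-yl, and how a 2-phenylethyl chain or an amine on the phenyl ring would read.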